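The compounds below may be only part of what the source reports. "The series", "measured", "known", "first", "only" and "open" are said of these compounds alone.

Measured so far:
- compound 1 `COc1cccc(NC(=O)/C=C/c2coc3cc(OC)ccc3c2=O)c1`: 39100 nM
- compound 2 `COc1ccc2c(=O)c(/C=C/C(=O)NCc3ccccc3F)coc2c1`: 34000 nM
- compound 3 `COc1ccc2c(=O)c(/C=C/C(=O)Nc3ccccc3OC)coc2c1`: 17600 nM

These three compounds were all tested in a functional assay (QGY7701 cells, Homo sapiens) for inhibition, read by MTT assay, with a stated time of 48 h; on this read-out higher numbers stand for weaker inhibition and lower numbers for stronger inhibition. Compound 3 separates from one neighbour, with a 2.2-fold lower number from compound 1 to compound 3 (0.35 log units; beyond the scatter), but not from the other, with a 1.9-fold lower number from compound 2 to compound 3 (0.29 log units; within the scatter). The next compound is compound 4 `COc1ccc2c(=O)c(/C=C/C(=O)NCc3ccc(F)cc3F)coc2c1`, which carries 2,4-difluorobenzyl in place of 2-methoxyphenyl on an amide-type nitrogen.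

Going by the values given here, no measured compound carries 2,4-difluorobenzyl, so the nearest guide is the 2-fluorobenzyl group of compound 2. Its exchange for 2-methoxyphenyl gave a 1.9-fold lower number from compound 2 to compound 3 (0.29 log units; within the scatter), and its arrival in place of 3-methoxyphenyl gave a 1.2-fold lower number from compound 1 to compound 2 (0.06 log units; within the scatter). Every change on this nitrogen has so far been small, so only a slight move towards a higher number is expected in this assay, one that stays within the scatter. The estimated step is a 1.7-fold higher number from compound 3 to compound 4 (0.23 log units; within the scatter). For compound 4 the expected value is 30000 nM, with an estimated range of 14000 nM to 60000 nM.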

Compound 4, half-maximal inhibitory concentration: > 100000 nM
Compound 4 was reported as a limit (the forecaster's own chance of this, stated with the estimate: 10%); middle value at least 3.3-fold (0.52 log units) away from the limit.
By their numbers in this assay, from the lowest: compounds 3, 2 and 1 (each within the scatter of the next, the first and the last beyond it). At a limit, above all of these: compound 4.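

In this assay compound 4 is reported only as a limit, > 100000 nM, and not as a number. Where earlier exchanges on this amide-type nitrogen moved the number little, fluoro in place of hydrogen on an aromatic carbon of the 2-fluorobenzyl group gives an at least 2.9-fold higher number from compound 2 to compound 4 (0.46 log units; beyond the scatter), so this position responds to a single atom exchange. The exchanges of the whole group are also larger than any earlier step, with an at least 5.6-fold higher number from compound 3 to compound 4 (0.75 log units; beyond the scatter) and an at least 2.5-fold higher number from compound 1 to compound 4 (0.40 log units; beyond the scatter), and both of these are lower bounds.

Going by these compounds, how far compound 4 lies past its limit stays unknown, and so does the true size of these steps. The compounds shown also leave open whether a chloro or methyl group in place of the added fluoro would give the same result.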